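Carboxylate and Hydroxyl Rearranged on the Outer Ring

This account rests on a few compounds, and the source may have more. Where it says the series, first, only, none or still open, it means among the compounds named here.

Going by the values given here, compound 2 `COc1ccc(C(=O)O)cc1-c1cccc(COc2ccc3c(c2)CN(C2CCCC2)C3=O)c1` is the one compound of this set with a number in an assay on HEK293 cells for positive allosteric modulation of metabotropic glutamate receptor 2 (Rattus norvegicus), read by thallium flux; a lower number here means that less compound is needed, a higher number that more compound is needed for the effect; compound 2 gives 80 nM. Compound 1 `O=C1c2ccc(OCc3cccc(-c4ccccc4)c3)cc2CN1C1CCCC1` shares the core but carries a plain phenyl. In this assay compound 1 reaches only a limit, > 5000 nM, and no number is known for it (the limit of > 5000 nM in this assay, at which 1 of the 2 values shown sits). Among the compounds with values here, the single measured step is therefore an at least 62-fold lower number from compound 1 to compound 2 (1.79 log units; beyond the scatter), a large one that sets a lower bound on the gain from the 5-carboxy-2-methoxyphenyl.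

Compound 3 `O=C(O)c1cc(-c2cccc(COc3ccc4c(c3)CN(C3CCCC3)C4=O)c2)ccc1O` alters that same outer ring: 3-carboxy-4-hydroxyphenyl in place of 5-carboxy-2-methoxyphenyl on an aromatic carbon. The carboxy is kept but moved, and the methoxy becomes a hydroxy. The step from compound 1 to compound 2 shows that this ring decides most of the activity, but it does not tell how far the carboxy can move or whether the methoxy matters. Compound 3 is expected to give 250 nM, with a range of 60 nM to 1500 nM. The estimate implies a modest loss, a 3.1-fold higher number from compound 2 to compound 3 (0.49 log units; beyond the scatter), with little certainty in either direction.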

Compound 3, half-maximal effective concentration: 20 nM
Beside the measured number, compound 3's estimate is 13-fold (1.10 log units) above it; measured number below the stated range.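

The 5-carboxy-2-methoxyphenyl is not the only form of this outer ring that carries activity: exchanging it for 3-carboxy-4-hydroxyphenyl, on the same aromatic carbon of the shared core, gives a 4.0-fold lower number from compound 2 to compound 3 (0.60 log units; beyond the scatter) in this assay. The methoxy is therefore not required for a low number here, and the carboxy tolerates a different place on the ring without any loss, at least when the hydroxy comes with it. The gain over the plain phenyl also grows, with an at least 250-fold lower number from compound 1 to compound 3 (2.39 log units; beyond the scatter), and this too is only a lower bound, since compound 1 is held at a limit and not at a number: the limit of > 5000 nM in this assay, at which 1 of the 3 values shown sits.

The carboxy and the oxygen substituent changed together, so the compounds shown cannot divide the improvement between the new place of the carboxy and the exchange of methoxy for hydroxy. Also open, as far as these compounds go, is whether the carboxylic acid itself is needed, or whether a tetrazole or a primary amide in its place on this ring would hold a comparable number, and whether a hydroxy alone on the ring would do anything.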